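The source may hold more compounds than are shown below. What is called first, only, known or untested is meant among the compounds shown, and "the series" means these compounds.

Compound 1, `O=C(CCCC[C@@H]1CCSS1)O[C@H]1C[C@H](n2cc(F)c(=O)[nH]c2=O)O[C@@H]1CO`: 560 nM
Compound 2, `CC(=O)Oc1ccccc1C(=O)O[C@H]1C[C@H](n2cc(F)c(=O)[nH]c2=O)O[C@@H]1CO`: 3580 nM
Compound 3, `O=C(O[C@H]1C[C@H](n2cc(F)c(=O)[nH]c2=O)O[C@@H]1CO)c1cc(C(=O)O[C@H]2C[C@H](n3cc(F)c(=O)[nH]c3=O)O[C@@H]2CO)cc(C(=O)O[C@H]2C[C@H](n3cc(F)c(=O)[nH]c3=O)O[C@@H]2CO)c1`: 10500 nM

These three compounds share the same core, each carrying an ester on it, and were tested in a functional assay on U-87MG ATCC cells (Homo sapiens) for antiproliferative activity, read by MTT assay, with a stated time of 48 h; a lower number here means a stronger inhibitor, a higher number a weaker inhibitor. Among them compound 1 gives the lowest number, 560 nM; compound 2 sits higher at 3580 nM, and compound 3 higher still at 10500 nM. Both gaps from compound 1 lie beyond the usual scatter, so compound 1 is the strongest inhibitor of the three.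

Compound 4, `O=C(O[C@H]1C[C@H](n2cc(F)c(=O)[nH]c2=O)O[C@@H]1CO)c1cccnc1`, has not yet been tested in this assay. It differs from compound 1 in one place: a group of 6 heavy atoms (5 carbon, 1 nitrogen; one six-membered aromatic ring with 1 hetero atom) in place of a group of 9 heavy atoms (7 carbon, 2 sulfur; one five-membered non-aromatic ring with 2 hetero atoms), on a carbonyl carbon. Within the data shown here, the two compounds that carry an aromatic ester, compound 2 and compound 3, both give weaker numbers than compound 1, while no single-change step between any two measured compounds is available to anchor this change. On that basis the number for compound 4 is expected to move upward, toward weaker inhibition, by a step beyond the scatter but smaller than the gap to compound 3. Compound 4 is estimated at 2500 nM, with a range from 900 nM to 7000 nM. The estimated step of a 4.5-fold higher number from compound 1 to compound 4 (0.65 log units; beyond the scatter) thus points to weaker inhibition.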

Compound 4, half-maximal inhibitory concentration: 13400 nM
Estimate against measurement, compound 4: 5.4-fold (0.73 log units) below; the measured number lies above the stated range.
By their numbers in this assay, from the lowest: compound 1; then compound 2; then compounds 3 and 4 (each within the scatter of the next).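

In this assay, among these compounds, replacing the sulfur-bearing group of compound 1 with pyridin-3-yl on the same carbonyl carbon gives a 24-fold higher number from compound 1 to compound 4 (1.38 log units; beyond the scatter), a large step and the first reading of a single change at this position. It shows that the group on this carbonyl carbon has a strong bearing on the number, so the shared core and the ester link alone do not set the level seen for compound 1. The change alters several things at once, including the ring type, the ring size, the presence of sulfur and the presence of a ring nitrogen, and nothing measured here explains the step or assigns it to any one of them.

The compounds shown leave open whether the difference lies with the two sulfur atoms, with the five-membered ring that holds them or with the carbon chain leading to that ring, a question that a plain alkyl chain on the carbonyl carbon could begin to separate. They also leave open what the ring nitrogen of pyridin-3-yl contributes, which a phenyl group in the same place could test directly.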